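Compound 3: (3-fluorophenyl)amino in place of piperidin-1-yl

A few compounds are considered here, and "the series" means these few. Any claim that something is new, unique, unknown or untested is made for them only; others in the source may bear on it.

Measured so far:
compound 1 `O=C1C(N2CCCCC2)=CC(=O)c2c1nc1n2[C@H]2OC[C@@H](O)[C@H]2OC1` — > 8000 nM
compound 2 `Cc1ccc(NC2=CC(=O)c3nc4n(c3C2=O)[C@H]2OC[C@@H](O)[C@H]2OC4)cc1` — 3480 nM

Two compounds of this series have been run in a functional assay on ECa-109 cells for inhibition, with ECa-109 cell line (Homo sapiens) as the target, read by sulforhodamine B assay; on this read-out lower numbers stand for stronger inhibition and higher numbers for weaker inhibition. Compound 1 gives only > 8000 nM, which is a limit of the assay and not a number, so the position of compound 1 on the scale is open; it stands at the limit of > 8000 nM in this assay, at which 1 of the 2 values shown sits. Compound 2 gives 3480 nM in this assay, a measured number. Both compounds carry the same core; compound 1 carries piperidin-1-yl on the double-bonded ring carbon, compound 2 an arylamino group there. Among the measured compounds shown here, no pair of measured compounds differs in a single place, so no measured step exists yet.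

Compound 3 `O=C1C(Nc2cccc(F)c2)=CC(=O)c2c1nc1n2[C@H]2OC[C@@H](O)[C@H]2OC1` is the next candidate. It differs from compound 1 by (3-fluorophenyl)amino in place of piperidin-1-yl on a double-bonded ring carbon. For the measured compounds named here, with only two values to go on, the expected step in this assay from compound 1 to compound 3 is toward stronger inhibition, of a size that would take compound 3 off the limit and into the region where compound 2 sits, yet the upper end of the range stays near the limit. For compound 3 the estimate is 3500 nM, between 1200 nM and 9000 nM, and the expected step is an at least 2.2-fold lower number from compound 1 to compound 3 (0.35 log units; beyond the scatter).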

Compound 3, half-maximal inhibitory concentration: 2370 nM
Beside the measured number, compound 3's estimate is 1.5-fold (0.17 log units) above it; the measured number falls inside the stated range.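

In this assay, the change on the double-bonded ring carbon now gives a measured step at this position, where none stood before: an at least 3.3-fold lower number from compound 1 to compound 3 (0.52 log units; beyond the scatter). The step therefore shows that this carbon tolerates an exchange of substituent with a read-out beyond the scatter, and that (3-fluorophenyl)amino lies on the stronger side of piperidin-1-yl. The exchange swaps a non-aromatic ring without a hydrogen-bond donor for an aromatic ring with one, and its full size cannot be read because compound 1 stands at a limit of the assay and not at a number: the limit of > 8000 nM in this assay, at which 1 of the 3 values shown sits.

A single step cannot separate the contribution of the aromatic ring from that of the hydrogen-bond donor, and cyclohexylamino or N-methyl-N-phenylamino at this carbon would pull the two apart. The part played by the fluorine also stays open, as the compounds shown include neither plain phenylamino nor a chlorine or methoxy group in its place on the (3-fluorophenyl)amino ring.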